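The source may hold more compounds than are shown below. What is called first, only, known or untested is meant among the compounds shown, and "the series" means these compounds.

Measured so far in a functional assay on the whole organism with Rattus norvegicus as the target, at a dose of 20 mg/kg by the oral route; on this read-out lower numbers stand for less inhibition and higher numbers for more inhibition at the one dose given (going by the name of the read-out):
- compound 1 `O=C(/C=C1\CCc2ccc(F)cc21)N1CCCC1`: 18%
- compound 2 `CNC(=O)/C=C1\CCc2ccc(F)cc21`: 38%

Compound 2 stands highest of the two numbers on this assay; the nearest is compound 1, the step of a number 20 percentage points higher from compound 1 to compound 2 (beyond the scatter) lying beyond the scatter. That step, methylamino in place of pyrrolidin-1-yl on a carbonyl carbon, is the only one in hand.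

Compound 3 `O=C(/C=C1\CCc2ccc(F)cc21)N1CCC1` has not been measured. It differs from compound 2 as follows: azetidin-1-yl in place of methylamino on a carbonyl carbon. The change runs back toward a cyclic amine on the carbonyl carbon, as in compound 1, though with azetidin-1-yl rather than pyrrolidin-1-yl. Among the measured compounds shown here, the one relevant step is a number 20 percentage points higher from compound 1 to compound 2 (beyond the scatter), which went the other way. A drop in this assay is therefore expected for compound 3, estimated at a number 13 percentage points lower from compound 2 to compound 3 (beyond the scatter), of comparable size or somewhat smaller, because only a number 20 percentage points higher from compound 1 to compound 2 (beyond the scatter) supports it. Compound 3 is expected to give 25%, within 10% to 42%.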

Compound 3, a percentage reported as inhibition, in the whole organism at one dose (the size of the read-out at that dose, not a potency): 0%
Compound 3: the middle estimate sits 25 percentage points above what was measured, outside the stated range (below it).
By their numbers in this assay, from the lowest: compound 3; then compound 1; then compound 2.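

In this assay, among the compounds shown here, this position on the carbonyl carbon proves more sensitive than the first pair showed, with a number 38 percentage points lower from compound 2 to compound 3 (beyond the scatter) as the largest step so far. The two cyclic amines also differ from each other, with a number 18 percentage points lower from compound 1 to compound 3 (beyond the scatter) for this change, so the read-out does not simply follow group size: compound 3, with the smaller ring, lies lowest, while compound 2 lies highest and compound 1 lies between them. No measurement bearing on the reason for either step is available.

Still open, on these data alone, is whether the higher number for compound 2 goes with its open chain or with the amide hydrogen. Dimethylamino, with no ring and no amide hydrogen, and ethylamino, a longer chain that keeps that hydrogen, would help separate the two.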